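Trifluoromethyl for Methoxy on the Aryl Piperazine

This account rests on a few compounds, and the source may have more. Where it says the series, first, only, none or still open, it means among the compounds named here.

Measured so far:
compound 1, `CCCc1nc(-c2ccccc2)c(CNCCN2CCN(c3ccccc3OC)CC2)o1`: 39.7%
compound 2, `CCCc1nc(-c2ccccc2)c(CNCCN2CCN(c3ccc(OC)cc3)CC2)o1`: 51.5%

Both compounds were tested in an assay on HEK293 cells for inhibition of Voltage-dependent T-type calcium channel subunit alpha-1G (Homo sapiens), read by fluorescence, tested at 10 uM; a higher number here means more inhibition at the concentration tested (going by the name of the read-out), a lower number less inhibition. Among the measured compounds shown here, compound 2 stands highest of the two numbers; its nearest neighbour, compound 1, lies below it, and the one measured step, a number 11.8 percentage points higher from compound 1 to compound 2 (beyond the scatter), is beyond the scatter. That step swaps the position of the methoxy on the phenyl ring attached to the piperazine nitrogen and says nothing about replacing the methoxy itself.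

Compound 3, `CCCc1nc(-c2ccccc2)c(CNCCN2CCN(c3ccc(C(F)(F)F)cc3)CC2)o1`, is not yet measured in this assay. It differs from compound 2 as follows: trifluoromethyl in place of methoxy on an aromatic carbon. Read one bond further out, the change is 4-methoxyphenyl to 4-(trifluoromethyl)phenyl. For the measured compounds named here, no measured step bears on this exchange of groups, so the account lacks any guide to its direction or size. On that basis compound 3 is expected to lie near compound 2, with a step of a number 0.5 percentage points higher from compound 2 to compound 3 (within the scatter) that stays within the scatter, and the estimate for compound 3 is 52%, with a range from 32% to 72%.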

Compound 3, a percentage reported as inhibition, at one concentration (the size of the read-out at that concentration, not a potency): 58.7%
For compound 3 the middle estimate is 6.7 percentage points below the measured one; the range from low to high includes it.
By their numbers in this assay, from the lowest: compound 1; then compounds 2 and 3 (each within the scatter of the next).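

In this assay, trifluoromethyl in place of methoxy, on the aromatic carbon para to a large group, gives a number 7.2 percentage points higher from compound 2 to compound 3 (within the scatter) and so leaves compound 2 and compound 3 inseparable, even though the two groups differ in their heavy atoms and in the hydrogen-bond acceptor counted on methoxy. The change from 2-methoxyphenyl to 4-(trifluoromethyl)phenyl gives a number 19 percentage points higher from compound 1 to compound 3 (beyond the scatter) and so, alongside the 4-methoxyphenyl compound, supplies a second compound that stands clear of compound 1 in this read-out, a pattern that holds for these three compounds only. Nothing available explains why these two groups cannot be told apart at this position or why both of these compounds stand clear of compound 1.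

The compounds shown leave open whether a carboxylic acid or an amine on the same aromatic carbon would stand apart from methoxy and trifluoromethyl in this assay. They also leave open whether 2-chlorophenyl would sit with 2-methoxyphenyl, and, with each compound read at a single concentration, how potency would compare across the series.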